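Replacing 4-hydroxyphenyl with ethyl on the amide carbonyl

The source may hold more compounds than are shown below. What is called first, only, known or untested is meant among the compounds shown, and "the series" means these compounds.

Of the compounds shown here, three have been measured in a toxicity assay on THP-1 cells (Homo sapiens) for inhibition (a higher number here means that more compound is tolerated, a lower number that less compound is tolerated), and every value is a limit of the assay rather than a number.
Compound 1 `COc1ccc(-c2cnc(NC(=O)c3ccn[nH]3)n2C)cc1` gives > 100000 nM.
Compound 2 `COc1ccc(-c2cnc(NC(=O)c3ccccc3)n2C)cc1` gives > 100000 nM.
Compound 3 `COc1ccc(-c2cnc(NC(=O)c3ccc(O)cc3)n2C)cc1` gives > 100000 nM.

Compound 3 therefore sits at the limit of > 100000 nM in this assay, at which 3 of the 3 values shown sit. The steps between the measured compounds cannot be read: a step that the two limits leave unreadable from compound 1 to compound 2, a step that the two limits leave unreadable from compound 1 to compound 3 and a step that the two limits leave unreadable from compound 2 to compound 3. Compound 4 `CCC(=O)Nc1ncc(-c2ccc(OC)cc2)n1C` differs from compound 3 by ethyl in place of 4-hydroxyphenyl on a carbonyl carbon. Among the compounds with values here, no measured step bears readably on this change, so no step beyond the scatter is expected; compound 4 is expected to stay at the same limit. Compound 4 is estimated at 150000 nM, between 50000 nM and 500000 nM, which means an expected step that the limit leaves unreadable from compound 3 to compound 4.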

Compound 4, half-maximal cytotoxic concentration: > 100000 nM
Compound 4 gave a limit, no number (the forecaster's own chance of this, stated with the estimate: 80%); the middle value is on the limit's open side.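

Within the data shown here, compound 4 gives a limit, as do compound 1, compound 2 and compound 3, so no step among them can be read: the limit of > 100000 nM in this assay, at which 4 of the 4 values shown sit. On these data alone, whether the groups on the carbonyl differ in their effect at all stays open.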